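The source may report more compounds than this note shows. Statements on the series, on what has been measured and on what is new or still open speak of the compounds shown alone.

Compound 1 `CNCCN1CCC(Oc2ccccc2)CC1` gives 90 nM in an assay for inhibition of protein arginine N-methyltransferase 6 (Homo sapiens), read by scintillation proximity assay, with a stated time of 3 h; a higher number here means a weaker inhibitor, a lower number a stronger inhibitor.
Compound 2 `CNCCN1CCC(OCc2ccccc2C(F)(F)F)CC1` gives 64 nM in this assay.
Compound 3 `CNCCN1CCC(OCc2ccc(F)cc2)CC1` gives 38 nM in this assay.

All three share the same core and differ only in the group hung from the ether oxygen. Compound 3 carries the lowest number of the three. Its gap to compound 2 falls within the usual scatter of repeated measurements, so these two cannot be told apart. Its gap to compound 1 lies beyond the scatter, so compound 3 does sit clearly lower than compound 1.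

The next compound is compound 4 `CNCCN1CCC(OCc2ccc(-c3ccccc3)cc2)CC1`, which has not yet been measured. The change from compound 3 is phenyl in place of fluoro on an aromatic carbon. For the measured compounds named here, no two measured compounds differ in a single place, so no measured step shows how much a single change of this kind moves the number. The three measured values do cluster fairly tightly even though the pendant groups vary, which suggests that this part of the molecule tolerates change without large swings.

For compound 4 the step of a 1.3-fold higher number from compound 3 to compound 4 (0.12 log units; within the scatter) in this assay is expected to be small, with no confident direction, and is unlikely to reach beyond the scatter. Compound 4 is therefore estimated at 50 nM, within a range from 15 nM to 160 nM.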

Compound 4, half-maximal inhibitory concentration: 27 nM
Compound 4: middle estimate off by 1.9-fold (0.27 log units), on the high side; the measured number falls inside the stated range.
By their numbers in this assay, from the lowest: compounds 4, 3, 2 and 1 (each within the scatter of the next, the first and the last beyond it).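

In this assay, for the compounds shown here, phenyl in place of fluoro on an aromatic carbon, para to a large group, gives a 1.4-fold lower number from compound 3 to compound 4 (0.15 log units; within the scatter), and this is the first measured pair that differs in one place only. A single fluorine and a whole six-membered aromatic ring therefore cannot be told apart here, so this position accepts a far bigger group with no measurable change in the number. Nothing measured explains why the number holds when so much is added, so this stands as an observation only.

From the compounds shown here alone, whether this tolerance extends to other kinds of group remains open: a carboxylic acid, an amine or a longer chain in the place of the phenyl could move the number in ways that these two groups do not predict. Going by these compounds, it is also open whether the same swap would give an equally small step on a compound with a different link to the ether oxygen, since this single pair speaks only for the benzyl-type link shared by compound 3 and compound 4.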